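Swapping the aryl ring on the alkyne of a modulator

The source may hold more compounds than are shown below. What is called first, only, known or untested is meant among the compounds shown, and "the series" means these compounds.

Measured so far in a functional assay on HEK293 cells for positive allosteric modulation of metabotropic glutamate receptor 5 (Rattus norvegicus), read by fluorescence and calcium flux; on this read-out higher numbers stand for larger maximal responses and lower numbers for smaller maximal responses:
- compound 1, `C[C@@H](NC(=O)c1ccc(C#Cc2ccccc2)cn1)C(C)(C)O`, gives 60.9%
- compound 2, `C[C@@H](NC(=O)c1ccc(C#Cc2ccc(F)cc2F)cn1)C(C)(C)O`, gives 61.2%
- compound 3, `Cc1ccccc1C#Cc1ccc(C(=O)N[C@H](C)C(C)(C)O)nc1`, gives 59.9%

All three compounds share the same core and differ only in the aryl ring attached to the triple-bonded carbon. Compound 2 sits within the scatter of both neighbours: the step of a number 0.3 percentage points higher from compound 1 to compound 2 (within the scatter) and the step of a number 1.3 percentage points lower from compound 2 to compound 3 (within the scatter) are both too small to count as real change, so the three numbers are effectively one number.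

Compound 4, `C[C@@H](NC(=O)c1ccc(C#Cc2cccnc2)cn1)C(C)(C)O`, has not yet been measured. It differs from compound 2 by pyridin-3-yl in place of 2,4-difluorophenyl on a triple-bonded carbon.

Going by the values given here, the steps that bear on this change are those that also swapped the ring on the triple-bonded carbon: a number 0.3 percentage points higher from compound 1 to compound 2 (within the scatter) and a number 1.3 percentage points lower from compound 2 to compound 3 (within the scatter), joined by a number 1 percentage points lower from compound 1 to compound 3 (within the scatter), which altered a substituent on that same ring. None of them moved the maximal response beyond the scatter, so no step beyond the scatter is expected in this assay for compound 4 either, in no particular direction. The expected step is a number 1.2 percentage points lower from compound 2 to compound 4 (within the scatter). The estimate for compound 4 is therefore 60%, within a range from 45% to 75%.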

Compound 4, largest response reached (reported as efficacy), in percent of the reference or control that the assay uses: 71.5%
Estimate against measurement, compound 4: 11.5 percentage points below; the measured number falls inside the stated range.
By their numbers in this assay, from the lowest: compounds 3, 1 and 2 (each within the scatter of the next); then compound 4.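

In this assay, going by these compounds alone, swapping the aryl ring on the triple-bonded carbon had so far left the maximal response unchanged, but pyridin-3-yl moves it beyond the scatter, with a number 10.3 percentage points higher from compound 2 to compound 4 (beyond the scatter), a number 10.6 percentage points higher from compound 1 to compound 4 (beyond the scatter) and a number 11.6 percentage points higher from compound 3 to compound 4 (beyond the scatter). All three steps are modest, yet the rings that leave sit within the scatter of one another, so this position separates pyridin-3-yl from all three rather than one of them from another. The counts show that pyridin-3-yl brings a ring nitrogen and a hydrogen-bond acceptor, which 2,4-difluorophenyl lacks, but no measurement here links the rise to either feature or gives any other explanation for it.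

On these data alone, with only pyridin-3-yl to go on, it stays open whether the ring nitrogen matters at all, or whether the gain is specific to this one ring. Also open, as far as these compounds go, is whether a phenyl ring carrying an amine, a nitrile or a carboxylic acid would raise the maximal response in the same way at this place.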